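This account rests on a few compounds, and the source may have more. Where it says the series, first, only, none or still open, it means among the compounds named here.

Compound 2 `CCCCCCCCCCCCCCCCCCNC(=O)[C@@H](NC(=O)c1cc2ccccc2n1C)[C@@H](C)O` holds the highest number of the two measured: in a functional assay on A-431 cells (Homo sapiens) for cytotoxicity, read by MTT assay, with a stated time of 48 h (a lower number here means a stronger inhibitor, a higher number a weaker inhibitor), compound 2 gives 61000 nM, while compound 1 `CCCCCCCCCCCCCCCCCCNC(=O)[C@@H](N)[C@@H](C)O` gives 21300 nM. Among the compounds with values here, the single measured step is a 2.9-fold higher number from compound 1 to compound 2 (0.46 log units; beyond the scatter). Compound 3 `CCCCCCCCCCCCCCCCCCNC(=O)[C@@H](NS(=O)(=O)c1cccs1)[C@@H](C)O` differs from compound 2 in that ((thiophen-2-yl)sulfonyl in place of (1-methyl-1H-indol-2-yl)carbonyl on an amine nitrogen). Within the data shown here, no measured step swaps one cap on that nitrogen for another; the one step only shows that capping the bare amine of compound 1 raised the number modestly. The number for compound 3 is therefore expected to stay near compound 2, estimated at 45000 nM with a range from 15000 nM to 130000 nM, a step of a 1.4-fold lower number from compound 2 to compound 3 (0.13 log units; within the scatter) within the scatter.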

Compound 3, half-maximal inhibitory concentration: > 200000 nM
Compound 3 ended at the assay's limit; the forecaster's own chance of this, stated with the estimate: 15%; middle value at least 4.4-fold (0.64 log units) away from the limit.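

The kind of cap on the amine nitrogen matters, not only its presence: (thiophen-2-yl)sulfonyl in place of (1-methyl-1H-indol-2-yl)carbonyl gives an at least 3.2-fold higher number from compound 2 to compound 3 (0.51 log units; beyond the scatter). Against the bare amine, the same cap gives an at least 9.3-fold higher number from compound 1 to compound 3 (0.97 log units; beyond the scatter). Compound 3 stands at > 200000 nM in this assay, which is a limit of the assay and not a number.

The compounds shown do not separate the sulfonyl link from the thiophene ring, as both change together. A (thiophen-2-yl)carbonyl cap or a benzenesulfonyl cap on this nitrogen would tell the two apart.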